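This account rests on a few compounds, and the source may have more. Where it says the series, first, only, none or still open, it means among the compounds named here.

Compound 1 `CCN(CC)c1ccc2cc(C(=O)NCCO)c(=O)oc2c1`: > 100000 nM
Compound 2 `CCN(CC)c1ccc2cc(C(=O)NN)c(=O)oc2c1`: 5480 nM

In a functional assay on HeLa cells (Homo sapiens) for cytotoxicity, read by MTT assay, with a stated time of 72 h (a lower number here means a stronger inhibitor, a higher number a weaker inhibitor), compound 1 gives > 100000 nM, which is a limit of the assay rather than a number. Compound 1 thus sits at the limit of > 100000 nM in this assay, at which 1 of the 2 values shown sits. Compound 2 gives 5480 nM, the only number shown. Compound 3 `CCN(CC)c1ccc2cc(C(=O)N/N=C(/C)c3cccnc3)c(=O)oc2c1` differs from compound 2 by a group of 9 heavy atoms (7 carbon, 2 nitrogen; one six-membered aromatic ring with 1 hetero atom) in place of one nitrogen atom, on an amide-type nitrogen. Among the compounds with values here, the single measured step, an at least 18-fold lower number from compound 1 to compound 2 (1.26 log units; beyond the scatter), also altered the group on this amide-type nitrogen, though in the reverse sense, and offers only loose guidance. The expected step is a 1.8-fold lower number from compound 2 to compound 3 (0.26 log units; within the scatter), a modest gain in this assay. Compound 3 is estimated at 3000 nM, with a range from 800 nM to 15000 nM.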

Compound 3, half-maximal inhibitory concentration: 70000 nM
Compound 3: middle estimate off by 23-fold (1.37 log units), on the low side; measured number outside the range, above it.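

On this amide-type nitrogen, the amino group of compound 2 proves hard to replace by something larger: in this assay, the group of 9 heavy atoms with its six-membered aromatic ring gives a 13-fold higher number from compound 2 to compound 3 (1.11 log units; beyond the scatter), so the amino group now stands apart from both other groups shown here. Against the 2-hydroxyethyl group, the new group gives an at least 1.4-fold lower number from compound 1 to compound 3 (0.15 log units; that floor lies within the scatter), which sets no order between them. The value of compound 1 is a limit of the assay: the limit of > 100000 nM in this assay, at which 1 of the 3 values shown sits.

On these data alone, what stays open is whether a small methyl group on this nitrogen would hold the number of compound 2. Also open, as far as these compounds go, is whether a six-membered aromatic ring without the double bond, joined through a one-carbon chain, would fare better.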